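Swapping the aryl end of a benzyl ether series

A few compounds are considered here, and "the series" means these few. Any claim that something is new, unique, unknown or untested is made for them only; others in the source may bear on it.

Compound 3 `O=[N+]([O-])c1ccccc1COc1ccc(OCCOCCNC2CCCC2)cc1` gives the lowest of the two numbers in a functional assay on SK-OV-3 cells (Homo sapiens) for inhibition, read by CCK-8 assay, with a stated time of 70 h (a lower number here means a stronger inhibitor, a higher number a weaker inhibitor), with 5370 nM. Compound 1 `c1ccc(COc2ccc(OCCOCCNc3cc[nH]c3)cc2)cc1` gives 11300 nM in this assay, the nearest number, separated from compound 3 by a gap beyond the scatter. Compound 2 `c1ccc(COc2ccc(OCCOCCOC3CCCC3)cc2)cc1` reaches only > 100000 nM in this assay, which is a limit rather than a number. Among the measured compounds shown here, the only measured step, an at least 8.8-fold higher number from compound 1 to compound 2 (0.94 log units; beyond the scatter), changes the far end of the chain, not the aryl group. Compound 4 `COC(=O)c1ccc(COc2ccc(OCCOCCNC3CCCC3)cc2)cc1` differs from compound 3 by 4-(methoxycarbonyl)phenyl in place of 2-nitrophenyl on a saturated chain carbon bound to an oxygen on an aromatic ring. No measured step alters this aryl group, so the change has no precedent among the shown compounds. The step of a 1.1-fold higher number from compound 3 to compound 4 (0.05 log units; within the scatter) is therefore expected to stay within the scatter. Compound 4 is estimated at 6000 nM, between 2500 nM and 15000 nM.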

Compound 4, half-maximal inhibitory concentration: 6990 nM
Compound 4: middle estimate off by 1.2-fold (0.07 log units), on the low side; the measured number falls inside the stated range.
By their numbers in this assay, from the lowest: compounds 3, 4 and 1 (each within the scatter of the next, the first and the last beyond it). At a limit, above all of these: compound 2.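

In this assay, among the compounds shown here, the aryl group on a saturated chain carbon bound to an oxygen on an aromatic ring changes for the first time, and a 1.3-fold higher number from compound 3 to compound 4 (0.11 log units; within the scatter) stays within the scatter. With the far end of the chain held constant, 4-(methoxycarbonyl)phenyl and 2-nitrophenyl cannot be told apart at this position, though that rests on this single pair. Nothing measured here accounts for that match. The compounds shown leave open how a carboxylic acid or an amine on this phenyl ring would read, and whether an unsubstituted phenyl with the cyclopentylamino chain end would match compound 3 and compound 4.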